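The source may report more compounds than this note shows. Statements on the series, on what has been measured and on what is new or still open speak of the compounds shown alone.

Compound 1, with the structure `O=C1C2CCCCN2C(=O)N1CCN1CCN(c2ccccc2)CC1`, was tested in an assay on isolated protein for binding affinity to Adrenergic receptor alpha-1 (Rattus norvegicus), read by radioligand binding; a higher number here means a weaker inhibitor, a lower number a stronger inhibitor. In this assay compound 1 gives only a limit, > 1000 nM, not a number. Compound 2, with the structure `O=C1C2CCCCN2C(=O)N1CCN1CCN(c2cccc(Cl)c2)CC1`, differs from it by a chloro in place of hydrogen on an aromatic carbon, and in this assay compound 2 gives 375 nM. That change gives an at least 2.6-fold lower number from compound 1 to compound 2 (0.42 log units; beyond the scatter), a step whose size can only be bounded because of the limit of > 1000 nM in this assay, at which 1 of the 2 values shown sits. Among the values shown, compound 2 therefore holds the only definite number, while the other entry is a limit.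

Compound 3, with the structure `O=C1C2CCCCN2C(=O)N1CCN1CCN(c2cccc(C(F)(F)F)c2)CC1`, carries the change (trifluoromethyl in place of chloro on an aromatic carbon). Among the measured compounds shown here, no measured step describes a swap of this kind; the only measured step is the one from compound 1 to compound 2, which shows that a group at this aromatic carbon can help, but it says nothing about exchanging one group for another there. A step of no more than modest size is expected in this assay, in either direction, and compound 3 is estimated at 320 nM, with a plausible range from 110 nM to 950 nM. That estimate means a 1.2-fold lower number from compound 2 to compound 3 (0.07 log units; within the scatter).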

Compound 3, inhibition constant: > 1000 nM
Compound 3 was reported as a limit; the forecaster's own chance of this, stated with the estimate: 15%; at least 3.1-fold (0.49 log units) between middle value and limit.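

The position does not treat every group alike: trifluoromethyl in place of chloro gives an at least 2.6-fold higher number from compound 2 to compound 3 (0.42 log units; beyond the scatter) in this assay. Among the compounds shown here, the earlier step showed only that one group at this aromatic carbon, meta to a large group, could lower the number, whereas this result shows that such a benefit does not extend to any group placed there. Among the three compounds shown, only chloro gives a definite number, so the benefit so far belongs to that single group and not to substitution at this carbon in general. Whether trifluoromethyl differs at all from hydrogen cannot be read, because compound 1 and compound 3 are both reported only as a limit: the limit of > 1000 nM in this assay, at which 2 of the 3 values shown sit.

The compounds shown leave open how a bromo, a methyl or a methoxy group would behave at this same aromatic carbon, and so whether chloro stands alone or belongs to a wider set of suitable groups. They also leave open whether chloro on another carbon of the same ring would give a lower number, a higher number or no change.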